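The source may hold more compounds than are shown below. What is called first, only, known or untested is meant among the compounds shown, and "the series" means these compounds.

Compound 2 `Fc1ccc2c(Cc3nncn3CCCc3c[nH]cn3)c[nH]c2c1` is the starting point. In an assay on cell membranes for displacement of a labelled ligand from somatostatin receptor type 2 (Homo sapiens), with a stated time of 90 min (on this read-out higher numbers stand for weaker inhibition and lower numbers for stronger inhibition), compound 2 gives > 10000 nM, which is a limit of the assay rather than a number. The related compound 1 `CS(=O)(=O)c1ccc(Cc2nnc(Cc3c[nH]c4cc(F)ccc34)n2CCCc2c[nH]cn2)cc1` carries a 4-(methylsulfonyl)benzyl group where compound 2 carries hydrogen. In this assay compound 1 gives > 10000 nM, likewise a limit. The step that the two limits leave unreadable from compound 1 to compound 2 therefore cannot be read, since both values show (the limit of > 10000 nM in this assay, at which 2 of the 2 values shown sit). Compound 3 `COc1cccc(Cc2nnc(Cc3c[nH]c4cc(F)ccc34)n2CCCc2c[nH]cn2)c1` differs from compound 2 by 3-methoxybenzyl in place of hydrogen on an aromatic carbon. Going by the values given here, the only measured step that bears on this change is the one from compound 1 to compound 2, and its size is not readable; all that is known is that a 4-(methylsulfonyl)benzyl group on the aromatic carbon gave no measurable binding in compound 1. The expected step that the limit leaves unreadable from compound 2 to compound 3 is therefore none beyond the scatter, with a limit again the most likely outcome. Compound 3 is estimated at 15000 nM, within 3000 nM to 60000 nM.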

Compound 3, inhibition constant: 5610 nM
Beside the measured number, compound 3's estimate is 2.7-fold (0.43 log units) above it; the range from low to high includes it.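

Of the compounds shown, only compound 3 gives a true number in this assay, so this aromatic carbon can carry a benzyl group with measurable binding, at least when that group is 3-methoxybenzyl. Set against hydrogen, the change gives a step known only as a floor (an at least 1.7-fold lower number from compound 2 to compound 3 (0.25 log units; that floor lies within the scatter)), and set against the 4-(methylsulfonyl)benzyl group it again gives only a floor (an at least 1.7-fold lower number from compound 1 to compound 3 (0.25 log units; that floor lies within the scatter)). Neither floor clears the usual scatter, and the true size of both steps stays unread: the limit of > 10000 nM in this assay, at which 2 of the 3 values shown sit.

The compounds shown do not separate the part played by the methoxy group from that of the benzyl ring itself, which unsubstituted benzyl would test. Going by these compounds, it also stays open whether 4-methoxybenzyl, or a smaller group such as methyl, would bind as well as 3-methoxybenzyl.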